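This account rests on a few compounds, and the source may have more. Where it says the series, first, only, none or still open, it means among the compounds named here.

Three compounds have been tested in a functional assay on SK-N-MC cells (Homo sapiens) for cytotoxicity, read by MTT assay; on this read-out lower numbers stand for stronger inhibition and higher numbers for weaker inhibition:

compound 1 `COc1ccc(/C=C2\CCC/C(=C\c3ccccc3[N+](=O)[O-])C2=O)cc1` gives 75 ug/mL
compound 2 `COc1cccc(/C=C2\CCC/C(=C\c3ccccc3[N+](=O)[O-])C2=O)c1` gives 4.49 ug/mL
compound 3 `COc1ccc(/C=C2\CCC/C(=C\c3cccc([N+](=O)[O-])c3)C2=O)cc1` gives 10.4 ug/mL

Compound 2 differs from compound 1 by 3-methoxyphenyl in place of 4-methoxyphenyl on a double-bonded chain carbon bound to a double-bonded ring carbon, and this change brought a 17-fold lower number from compound 1 to compound 2 (1.22 log units; beyond the scatter). Compound 3 and compound 1 share the same atoms joined differently, but the difference between the two cores is not broken down here; their values show compound 3 giving the lower number.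

Compound 4 `COc1cccc(/C=C2\CCC/C(=C\c3cccc([N+](=O)[O-])c3)C2=O)c1` is not yet measured. It differs from compound 3 by 3-methoxyphenyl in place of 4-methoxyphenyl on a double-bonded chain carbon bound to a double-bonded ring carbon, the same change as that from compound 1 to compound 2. For the measured compounds named here, because that step was a 17-fold lower number from compound 1 to compound 2 (1.22 log units; beyond the scatter), a lower number is expected for compound 4 in this assay, though with only one earlier instance the size is uncertain, so a somewhat smaller step, a 6.9-fold lower number from compound 3 to compound 4 (0.84 log units; beyond the scatter), is estimated. Compound 4 is therefore expected to give about 1.5 ug/mL, within a range of 0.4 ug/mL to 5 ug/mL.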

Compound 4, half-maximal inhibitory concentration: 4.94 ug/mL
For compound 4 the middle estimate is 3.3-fold (0.52 log units) below the measured one; low and high end bracket the measured number.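

In this assay, 3-methoxyphenyl in place of 4-methoxyphenyl again lowered the number, giving a 2.1-fold lower number from compound 3 to compound 4 (0.32 log units; beyond the scatter), so the direction of the change held on both cores. The size of the step did not carry over, and the two steps differ beyond the scatter: the same change on two cores in this assay, a 17-fold lower number (1.22 log units; beyond the scatter) from compound 1 to compound 2 and a 2.1-fold lower number (0.32 log units; beyond the scatter) from compound 3 to compound 4, 7.9-fold (0.90 log units) apart, beyond the scatter of two such steps. This shows that the size of the step depends on the core carrying the change, but two cores cannot show how the change would behave on a third, and these numbers do not show why the steps differ.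

As far as these compounds go, what a hydroxyl group or a chlorine atom in place of the methoxy group would give remains open. From the compounds shown here alone, it is also open whether the same change would lower the number on a core carrying an amine in place of the nitro group.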